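The compounds below may be only part of what the source reports. "The series", "measured", "known", "first", "only" and "open" are said of these compounds alone.

Compound 2 `CCOC(=O)C1=C(C)NC(=S)NC1c1cn(C(=O)CNc2ccc([N+](=O)[O-])c(Cl)c2)c2ccccc12` gives 50 ug/mL in a functional assay on MCF7 cells (Homo sapiens) for cytotoxicity, read by MTT assay, with a stated time of 72 h; a lower number here means a stronger inhibitor, a higher number a weaker inhibitor. That places compound 2 level, at the digits shown, with compound 3 `CCOC(=O)C1=C(C)NC(=O)NC1c1cn(C(=O)CNc2ccc([N+](=O)[O-])cc2C)c2ccccc12`, which gives 50 ug/mL, and within the scatter of compound 1 `CCOC(=O)C1=C(C)NC(=S)NC1c1cn(C(=O)CNc2ccccc2)c2ccccc12`, which gives 52 ug/mL. Within the data shown here, the one measured single step, a 1.0-fold lower number from compound 1 to compound 2 (0.02 log units; within the scatter), is flat. Compound 4 `CCOC(=O)C1=C(C)NC(=S)NC1c1cn(C(=O)CNc2ccccc2[N+](=O)[O-])c2ccccc12` differs from compound 2 in one place: 2-nitrophenyl in place of 3-chloro-4-nitrophenyl on an amine nitrogen. The step that bears on this change is the earlier swap at the same amine nitrogen, a 1.0-fold lower number from compound 1 to compound 2 (0.02 log units; within the scatter), which did not move the number beyond the scatter, and no other comparison exists. No shift beyond the scatter is therefore expected. Compound 4 is expected to give about 50 ug/mL, between 25 ug/mL and 100 ug/mL. That estimate amounts to no change at the digits printed from compound 2 to compound 4 (within the scatter).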

Compound 4, half-maximal inhibitory concentration: 550 ug/mL
Compound 4: middle estimate off by 11-fold (1.04 log units), on the low side; the measured number lies above the stated range.
By their numbers in this assay, from the lowest: compounds 2, 3 and 1 (each within the scatter of the next); then compound 4.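

Adding a nitro group to the phenyl of compound 1 to give 2-nitrophenyl brings an 11-fold higher number from compound 1 to compound 4 (1.02 log units; beyond the scatter), and replacing 3-chloro-4-nitrophenyl with 2-nitrophenyl brings an 11-fold higher number from compound 2 to compound 4 (1.04 log units; beyond the scatter). This amine nitrogen's aromatic substituent can therefore move the number strongly, yet having a nitro group does not by itself decide the outcome, since compound 2 also carries one and remains within the scatter of compound 1. No measurement here accounts for the jump. As far as these compounds go, it remains open whether 2-methoxyphenyl or 2-aminophenyl on this nitrogen would raise the number as well.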